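Swapping the dichlorophenyl amide for an ethyl oxamate

This account rests on a few compounds, and the source may have more. Where it says the series, first, only, none or still open, it means among the compounds named here.

Compound 1 `COc1cc(/C=C/C(=O)c2cccc(NC(=O)c3ccc(Cl)c(Cl)c3)c2)ccc1O` was tested in a functional assay on Vero cells (Chlorocebus sabaeus) for inhibition (on this read-out higher numbers stand for weaker inhibition and lower numbers for stronger inhibition), and there compound 1 gives only a limit, > 50 ug/mL. The same limit, (the limit of > 50 ug/mL in this assay, at which 2 of the 3 values shown sit), is shared with compound 3 `COc1cc(/C=C/C(=O)c2cccc(NC(=O)c3cc(Cl)cc(Cl)c3)c2)ccc1O`, for which this assay records > 50 ug/mL. Compound 2 `COc1cc(/C=C/C(=O)c2cccc(NC(=O)c3ccccc3)c2)ccc1O`, which carries a plain phenyl on the carbonyl carbon, is the only one of the three with a number: in this assay compound 2 gives 3.47 ug/mL. The step of an at least 14-fold lower number from compound 1 to compound 2 (1.15 log units; beyond the scatter) is large, and its counterpart an at least 14-fold higher number from compound 2 to compound 3 (1.15 log units; beyond the scatter) is large in the opposite direction, so within this small set the dichlorinated aryl groups sit at the limit while the unsubstituted one does not.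

Compound 4 `CCOC(=O)C(=O)Nc1cccc(C(=O)/C=C/c2ccc(O)c(OC)c2)c1` differs from compound 1 as follows: ethoxycarbonyl in place of 3,4-dichlorophenyl on a carbonyl carbon. Among the compounds with values here, no measured step shows an ethoxycarbonyl on that carbonyl carbon, so the only guidance is that leaving 3,4-dichlorophenyl, as in the step to compound 2, moved the number off the limit. Compound 4 is therefore expected to land below the limit, with the step of an at least 3.3-fold lower number from compound 1 to compound 4 (0.52 log units; beyond the scatter), though with wide uncertainty. The estimate for compound 4 is 15 ug/mL, within a range from 3 ug/mL to 50 ug/mL.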

Compound 4, half-maximal inhibitory concentration: > 50 ug/mL
Compound 4 gave a limit, no number; the forecaster's own chance of this, stated with the estimate: 35%; middle value at least 3.3-fold (0.52 log units) away from the limit.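

The result shows that keeping chlorine off this carbonyl carbon's substituent is not enough to move the value off the limit in this assay: ethoxycarbonyl, with no ring and no chlorine, behaves here like the two dichlorophenyl groups. Of the four groups on this carbonyl carbon, only the phenyl of compound 2 gives a number, and exchanging it for ethoxycarbonyl gives an at least 14-fold higher number from compound 2 to compound 4 (1.15 log units; beyond the scatter), while the steps linking compound 4 with compound 1 and compound 3 cannot be read. Compound 4 therefore joins the compounds that give only a limit: the limit of > 50 ug/mL in this assay, at which 3 of the 4 values shown sit.

From the compounds shown here alone, how far compound 1, compound 3 and compound 4 differ from one another beyond that limit remains open. Also open, going by these compounds, is whether a single chlorine on the phenyl, or a carboxylic acid in place of the ethyl ester, would give a number.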